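The source may report more compounds than this note shows. Statements on the series, on what has been measured and on what is new or still open speak of the compounds shown alone.

Compound 2, with the structure `CCOC(=O)N1CCC(NC(=O)Nc2ccc(OC(F)(F)F)c(F)c2)CC1`, is the starting point of this step. In a physicochemical assay for lipophilicity, read by HPLC, with a stated time of 90 min, tested at 100 uM (a lower number here means a more polar compound, a higher number a more lipophilic compound), compound 2 gives 5.94, the second highest of the three numbers measured. Among the compounds with values here, its nearest neighbour is compound 1, `CCOC(=O)N1CCC(NC(=O)Nc2ccc(C(F)(F)F)c(F)c2)CC1`, which in this assay gives 5.46; the only single-place step measured, a number 0.48 log units higher from compound 1 to compound 2 (beyond the scatter), is beyond the scatter and of modest size, and consists of trifluoromethoxy in place of trifluoromethyl on an aromatic carbon. Within the data shown here, the furthest is compound 3, `CC[C@H](C)C(=O)N1CCC(NC(=O)Nc2ccc(OC(F)(F)F)c(Br)c2)CC1`, which in this assay gives 8.07; compound 3 differs from compound 2 in more than one place, so the two values show only that compound 3 sits well above compound 2.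

Compound 4, `O=C(Nc1ccc(OC(F)(F)F)c(F)c1)NC1CCN(C(=O)C2CCCOC2)CC1`, has not yet been measured. It differs from compound 2 as follows: oxan-3-yl in place of ethoxy on a carbonyl carbon. Among the measured compounds shown here, no measured step bears directly on an exchange at the carbonyl carbon; the step from compound 1 to compound 2 concerns the aromatic ring and says nothing about it. For the measured compounds named here, the values of compound 2 and compound 3 suggest only that a larger group on that carbonyl can go with a much higher number. Compound 4 is therefore expected to come out somewhat higher, a step of a number 0.36 log units higher from compound 2 to compound 4 (beyond the scatter). The estimate for compound 4 in this assay is 6.3, within a range of 5.7 to 6.9.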

Compound 4, partition coefficient: 4.09
Beside the measured number, compound 4's estimate is 2.21 log units above it; measured number outside the range, below it.
By their numbers in this assay, from the lowest: compound 4; then compound 1; then compound 2; then compound 3.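

The carbonyl carbon proves to be a place where this read-out moves strongly: in this assay the exchange of ethoxy for oxan-3-yl gives a number 1.85 log units lower from compound 2 to compound 4 (beyond the scatter) and so goes in the opposite direction to the modest ring exchange, a number 0.48 log units higher from compound 1 to compound 2 (beyond the scatter). The entering group has 6 heavy atoms and a six-membered non-aromatic ring against 3 heavy atoms and no ring in the leaving group, while both carry 1 hydrogen-bond acceptor, 0 hydrogen-bond donors and no net charge, so in this one pair more heavy atoms go with a lower number, and those counts of acceptors, donors and charge do not separate the two groups. Nothing measured on these groups accounts for the size or direction of this step.

The compounds shown leave open whether the ring oxygen of oxan-3-yl or the change from ethoxycarbonyl to a ring-bearing carbonyl goes with the lower number, a question that cyclohexyl on the same carbonyl carbon would address. They also leave open how oxan-4-yl, or a simple amine on that carbonyl carbon, would read in this assay, and whether the step would hold with trifluoromethyl on the aromatic ring.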